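Glycoside aryl ethers: ring-position swap of the isopropylphenyl group

The compounds below may be only part of what the source reports. "The series", "measured", "known", "first", "only" and "open" are said of these compounds alone.

Measured so far:
compound 1 `CO[C@H]1O[C@H](COc2ccccc2C(C)C)[C@@H](O)[C@H](O)[C@H]1Oc1ccc(OC2CCCCC2)cc1` 47000 nM
compound 2 `CO[C@@H]1O[C@H](COc2cccc(C(C)C)c2)[C@@H](O)[C@H](O)[C@H]1Oc1ccc(OC2CCCCC2)cc1` 39000 nM

In a functional assay on HeLa cells (Homo sapiens) for cytotoxicity, read by MTT assay, with a stated time of 48 h (a higher number here means that more compound is needed for the effect, a lower number that less compound is needed), compound 2 gives 39000 nM, the lower of the two numbers recorded; the nearest is compound 1, whose value lies within the usual scatter of the method, so the two cannot be ordered. Compound 3 `CO[C@@H]1O[C@H](COc2ccccc2C(C)C)[C@@H](O)[C@H](O)[C@H]1Oc1ccc(OC2CCCCC2)cc1` has not yet been measured in this assay. It keeps every atom of compound 2, joined differently: 2-isopropylphenyl in place of 3-isopropylphenyl on an oxygen on a saturated carbon. Within the data shown here, no measured pair differing in a single place is available, so the size of this step is unknown. Compound 1 also carries a 2-isopropylphenyl group and sits close to compound 2, which argues for no step beyond the scatter. The expected outcome is therefore a flat move, a 1.1-fold higher number from compound 2 to compound 3 (0.04 log units; within the scatter). Compound 3 is estimated at 43000 nM, with a range from 20000 nM to 90000 nM.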

Compound 3, half-maximal effective concentration: 42000 nM
For compound 3 the middle estimate is 1.0-fold (0.01 log units) above the measured one, within the range that was stated.
By their numbers in this assay, from the lowest: compounds 2, 3 and 1 (each within the scatter of the next).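

In this assay, 2-isopropylphenyl in place of 3-isopropylphenyl on an oxygen on a saturated carbon gives a 1.1-fold higher number from compound 2 to compound 3 (0.03 log units; within the scatter), so this ring-position swap has no readable effect on its own. Inverting the drawn stereocentre at a saturated ring carbon gives a 1.1-fold lower number from compound 1 to compound 3 (0.05 log units; within the scatter), which is also flat and separates configuration from the ring-position swap, two changes that were combined in the earlier pair of compounds. This reading of configuration alone rests on one fact: the fact that compounds 1 and 3 differ only in the configuration as drawn

On these data alone, it remains open whether replacing the isopropyl group with a different substituent, such as an amine or a carboxylic acid, would shift the number beyond the scatter. As far as these compounds go, it is also open whether changes to the other aryl ether on the shared core would do so.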